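The compounds below may be only part of what the source reports. "The series", "measured", "known", "first", "only" and "open" are said of these compounds alone.

Working notes on the series. Within the data shown here, compound 3 `c1ccc(OCc2nc3c(OCCCN4CCCCC4)cccc3n2CCCC2CCNCC2)cc1` is the one member with an unsubstituted ring nitrogen and gives 4.5 nM in an in vitro assay on AV12 cells for binding affinity to Neuropeptide Y receptor type 1 (Homo sapiens) (a higher number here means a weaker inhibitor, a lower number a stronger inhibitor), the highest number of the three measured. Compound 1 `C=CCCN1CCC(CCCn2c(COc3ccccc3)nc3c(OCCCN4CCCCC4)cccc32)CC1` carries but-3-en-1-yl on that nitrogen and gives 0.707 nM; compound 2 `c1ccc(OCc2nc3c(OCCCN4CCCCC4)cccc3n2CCCC2CCN(CCCN3CCCCC3)CC2)cc1` carries 3-(piperidin-1-yl)propyl there and gives 0.106 nM. Among the measured compounds shown here, both steps that end at compound 3, a 6.4-fold higher number from compound 1 to compound 3 (0.80 log units; beyond the scatter) and a 42-fold higher number from compound 2 to compound 3 (1.63 log units; beyond the scatter), show the bare ring nitrogen as the weaker arrangement on the numbers so far, and a 6.7-fold lower number from compound 1 to compound 2 (0.82 log units; beyond the scatter) shows the further gain when the side chain carries a second amine.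

Compound 4 `c1ccc(OCc2nc3c(OCCCN4CCCCC4)cccc3n2CCCC2CCN(CC3CCCCC3)CC2)cc1` changes the same position: cyclohexylmethyl in place of hydrogen on an amine nitrogen in a ring. Cyclohexylmethyl, like but-3-en-1-yl, brings carbon only and no further nitrogen, so the nearest comparison is a 6.4-fold higher number from compound 1 to compound 3 (0.80 log units; beyond the scatter) rather than a 42-fold higher number from compound 2 to compound 3 (1.63 log units; beyond the scatter). A reversal of the first of these is the expectation; the data give no ground to expect the larger gain that went with 3-(piperidin-1-yl)propyl. Compound 4 is therefore estimated at 0.6 nM, with a range of 0.2 nM to 2 nM, an expected step of a 7.5-fold lower number from compound 3 to compound 4 (0.88 log units; beyond the scatter).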

Compound 4, inhibition constant: 0.393 nM
Compound 4: the middle estimate sits 1.5-fold (0.18 log units) above what was measured; low and high end bracket the measured number.
By their numbers in this assay, from the lowest: compound 2; then compounds 4 and 1 (each within the scatter of the next); then compound 3.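

In this assay, an 11-fold lower number from compound 3 to compound 4 (1.06 log units; beyond the scatter) shows that a substituent of carbon only, here one holding a six-membered ring, is enough for a large gain over hydrogen on the ring nitrogen, while a 1.8-fold lower number from compound 1 to compound 4 (0.26 log units; within the scatter) leaves cyclohexylmethyl and but-3-en-1-yl unseparated, so the open chain and the ring-bearing group cannot be told apart at this position. Against that, a 3.7-fold higher number from compound 2 to compound 4 (0.57 log units; beyond the scatter) shows that 3-(piperidin-1-yl)propyl keeps a lead beyond the scatter over cyclohexylmethyl, as it does over but-3-en-1-yl, so the advantage of the side chain with a second amine holds against two different carbon-only groups. Nothing available on these compounds accounts for any of these steps.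

Still open, on these data alone, is whether the lead of compound 2 belongs to the second amine or to the length of its chain, which a plain hexyl chain or a dimethylamino group on a shorter chain would help to separate. Also open, as far as these compounds go, is how the ring nitrogen behaves with a substituent of another kind, such as an acetyl group or a chain ending in a carboxylic acid.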